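Same Swap, Second Core: Methyl to Phenyl Again

This account rests on a few compounds, and the source may have more. Where it says the series, first, only, none or still open, it means among the compounds named here.

The study gathers four compounds that share most of their framework. Compound 1 `COC(=O)c1ccc(-c2cn(CCCC(=O)Nc3ccc(C)cc3)nn2)cc1` and compound 2 `COC(=O)c1ccc(-c2cn(CCCC(=O)Nc3ccc(-c4ccccc4)cc3)nn2)cc1` differ in a single place: phenyl in place of methyl on an aromatic carbon. Compound 3 `COC(=O)c1ccc(-c2cn(CCCC(=S)Nc3ccc(C)cc3)nn2)cc1` rests on a different core; the difference between the core of compound 3 and the core of compound 1 is not broken down here. Compound 4 `COC(=O)c1ccc(-c2cn(CCCC(=S)Nc3ccc(-c4ccccc4)cc3)nn2)cc1` has not yet been measured and stands to compound 3 as compound 2 stands to compound 1.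

In a functional assay on MDA-MB-231 cells (Homo sapiens) for inhibition, read by MTT assay, with a stated time of 72 h (a higher number here means a weaker inhibitor, a lower number a stronger inhibitor), compound 1 gives 2700 nM. Compound 2 in this assay reaches only a limit of the assay, > 100000 nM. The change between them therefore registers as an at least 37-fold higher number from compound 1 to compound 2 (1.56 log units; beyond the scatter), a step whose size is set by the limit of > 100000 nM in this assay, at which 2 of the 3 values shown sit, rather than by a measured number. Compound 3 in this assay likewise gives only a limit, > 100000 nM.

Compound 4 differs from compound 3 by the same change, (phenyl in place of methyl on an aromatic carbon), at the same place on the terminal ring. Among the measured compounds shown here, only one instance of this change has been measured, and it came out large. Since compound 3 already gives > 100000 nM, compound 4 is expected to move by about a step that the limit leaves unreadable from compound 3 to compound 4, which here can mean only staying at or beyond the limit. Compound 4 is therefore expected to give roughly 150000 nM in this assay, most probably again reported as a limit rather than a number.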

Compound 4, half-maximal inhibitory concentration: > 100000 nM
Compound 4: only a limit was reported (the forecaster's own chance of this, stated with the estimate: 85%); the middle value does not contradict the limit.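

Compound 4 in this assay gives > 100000 nM as a limit of the assay and not a number. No step from compound 3 to compound 4 can be read, because both compounds sit at the same limit: the limit of > 100000 nM in this assay, at which 3 of the 4 values shown sit.

The compounds shown leave open whether phenyl in place of methyl changes anything on the core of compound 3, and how far past the limit compound 2, compound 3 and compound 4 actually lie.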